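This account rests on a few compounds, and the source may have more. Where it says the series, first, only, none or still open, it means among the compounds named here.

Working notes on a functional assay on HeLa cells (Homo sapiens) for antiproliferative activity, with a stated time of 48 h; a lower number here means a stronger inhibitor, a higher number a weaker inhibitor. Compound 1 `Cc1cc(=O)c2c(OCC3CO3)cc(OCC3CO3)cc2o1`, drawn without configuration at its two stereocentres, gives 5400 nM. Compound 2 `Cc1cc(=O)c2c(OC[C@H]3CO3)cc(OC[C@H]3CO3)cc2o1` gives 11400 nM, and compound 3 `Cc1cc(=O)c2c(OC[C@@H]3CO3)cc(OC[C@H]3CO3)cc2o1` gives 11000 nM. Compound 3 therefore stands level with compound 2, with a 1.0-fold lower number from compound 2 to compound 3 (0.02 log units; within the scatter) inside the scatter, and apart from compound 1, with a 2.0-fold higher number from compound 1 to compound 3 (0.31 log units; beyond the scatter) modest but beyond it. The companion step, a 2.1-fold higher number from compound 1 to compound 2 (0.32 log units; beyond the scatter), is of the same modest size.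

Compound 4 `Cc1cc(=O)c2c(OC[C@H]3CO3)cc(OC[C@@H]3CO3)cc2o1` is the mirror image of compound 3: the two compounds have the same atoms and bonds and differ only in configuration as drawn: 2 of 2 stereo elements differ (all stereocentres are inverted: mirror images); a stereocentre at a saturated ring carbon is drawn S in compound 3 and R in compound 4; a stereocentre at a saturated ring carbon is drawn R in compound 3 and S in compound 4. Among the compounds with values here, no measured step inverts both stereocentres at once. The closest guide is a 1.0-fold lower number from compound 2 to compound 3 (0.02 log units; within the scatter), which rests on the fact that compounds 2 and 3 differ only in the configuration as drawn and shows that inverting one stereocentre left the number within the scatter. The two steps from compound 1 are looser guides, resting on the fact that one of compounds 1 and 2 is drawn with a defined configuration and the other without, at the place where they differ and on (the fact that one of compounds 1 and 3 is drawn with a defined configuration and the other without, at the place where they differ). Compound 1, at 5400 nM, still leaves open a somewhat lower number for an undrawn configuration, so a slight lean in that direction is allowed. No clear step beyond the scatter is expected in this assay. The expected step is a 1.2-fold lower number from compound 3 to compound 4 (0.06 log units; within the scatter), and it is small. For compound 4 the estimated value is 9500 nM, with an expected range of 4500 nM to 20000 nM.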

Compound 4, half-maximal inhibitory concentration: 1770 nM
For compound 4 the middle estimate is 5.4-fold (0.73 log units) above the measured one, and the stated range ends above it.
By their numbers in this assay, from the lowest: compound 4; then compound 1; then compounds 3 and 2 (each within the scatter of the next).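

In this assay, configuration alone now moves the number beyond the scatter between two fully defined compounds, with a 6.2-fold lower number from compound 3 to compound 4 (0.79 log units; beyond the scatter) for the mirror-image pair: the fact that compounds 3 and 4 differ only in the configuration as drawn. Inversion at one stereocentre gives a 1.0-fold lower number from compound 2 to compound 3 (0.02 log units; within the scatter), while inversion at the other gives a 6.4-fold lower number from compound 2 to compound 4 (0.81 log units; beyond the scatter), so the two stereocentres do not count alike in this series: the fact that compounds 2 and 4 differ only in the configuration as drawn. Compound 4 also stands clear of the compound drawn without configuration, with a 3.1-fold lower number from compound 1 to compound 4 (0.48 log units; beyond the scatter), which makes it the strongest inhibitor of the four compounds shown: the fact that one of compounds 1 and 4 is drawn with a defined configuration and the other without, at the place where they differ.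

The remaining combination of the two stereocentres, the mirror image of compound 2, is not among the compounds shown, so it stays open whether the lower number of compound 4 follows from one stereocentre alone or from the particular pairing of both. From the compounds shown here alone, it also stays open whether the gap between compound 3 and compound 4 would persist with an amine or a longer chain in place of either saturated ring on the shared core.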